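The source may report more compounds than this note shows. Statements on the series, on what has been measured and on what is new or still open speak of the compounds shown alone.

Measured compounds in a physicochemical assay for solubility, read by turbidimetry, measured as kinetic solubility, at pH 6.8; on this read-out higher numbers stand for higher solubility and lower numbers for lower solubility:

Compound 1, `Cc1cccc(N2C(=O)CSC2c2cccc(C(=O)NCCCCc3ccccc3)c2)c1`: in this assay compound 1 gives 10000 nM
Compound 2, `Cc1ccnc(N2C(=O)CSC2c2cccc(C(=O)NCCCCn3cccn3)c2)c1`: in this assay compound 2 gives 50000 nM
Compound 3, `O=C(NCCCCc1ccccc1)c1cccc(C2SCC(=O)N2c2cccc(F)c2)c1`: in this assay compound 3 gives 10000 nM

Compound 2 stands highest of the three, and its values against compound 1 and compound 3 lie beyond the scatter. The difference between the cores of compound 1 and compound 2 is not broken down here.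

Compound 3 arises from compound 1 by fluoro in place of methyl on an aromatic carbon, and that step reads no change at the digits printed from compound 1 to compound 3 (within the scatter) in this assay. The unmeasured compound 4, `O=C(NCCCCn1cccn1)c1cccc(C2SCC(=O)N2c2cc(F)ccn2)c1`, arises from compound 2 by fluoro in place of methyl on an aromatic carbon. This is the same kind of change, yet not the same: in compound 1 the place is on a six-membered aromatic ring of carbon only, meta to a large group, whereas in compound 2 it is on a six-membered aromatic ring with 1 nitrogen, meta to a large group and opposite the ring nitrogen.

Resting on the flat step seen from compound 1 to compound 3, the expected step from compound 2 to compound 4 is no change at the digits printed from compound 2 to compound 4 (within the scatter), set beside no change at the digits printed from compound 1 to compound 3 (within the scatter). For compound 4 the estimated value in this assay is 50000 nM, expected to fall between 20000 nM and 100000 nM.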

Compound 4, solubility: 50000 nM
The estimate for compound 4 equals the measured number at the digits printed; measured number inside the range.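

In this assay, fluoro in place of methyl on an aromatic carbon gives no change at the digits printed from compound 2 to compound 4 (within the scatter) on the core of compound 2, and on the core of compound 1 the same kind of change gave no change at the digits printed from compound 1 to compound 3 (within the scatter) in the same assay. The swap therefore read flat on both cores, with no compound among these pairs going against that, but this rests on only two pairs, at a single place on each core, and it does not show that the swap would stay flat on any further core in the series. Nothing measured here bears on why the step reads the same on both cores.

The compounds shown leave open whether a group of another kind at the same place, such as an amine or a carboxylic acid, would also leave the read-out flat. They also leave open whether the swap would read the same with a longer chain in place of the butyl linker.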